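The source may hold more compounds than are shown below. What is called first, only, known or untested is meant among the compounds shown, and "the series" means these compounds.

Compound 1, with the structure `O=S1(=O)c2ccccc2CN1c1cc(F)cc(Oc2cccnc2)c1`, was tested in a functional assay on Flp-In T-REx293 cells for antagonist activity at Free fatty acid receptor 1 (Homo sapiens), read by calcium flux; on this read-out lower numbers stand for stronger inhibition and higher numbers for weaker inhibition. In this assay compound 1 gives > 100000 nM, which is a limit of the assay rather than a measured number, so compound 1 is known only to sit at that limit (the limit of > 100000 nM in this assay, at which 1 of the 2 values shown sits). Within the data shown here, compound 2, with the structure `CCCCc1ccc(NS(=O)(=O)c2ccc(F)cc2)cc1`, belongs to the same set and in this assay compound 2 gives 8130 nM; it differs from compound 1 in more than one place, so no single step between the two is drawn.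

The compound still to be measured is compound 3, with the structure `Cc1cccc(Oc2cc(F)cc(N3Cc4ccccc4S3(=O)=O)c2)c1`. It differs from compound 1 in one place: 3-methylphenyl in place of pyridin-3-yl on an oxygen on an aromatic ring. Among the measured compounds shown here, no measured pair in this set shows what that exchange does, so the direction of the step can only be guessed. Compound 1 sits at the limit of the assay, which leaves room for compound 3 to move toward a measurable number, but also leaves open that it stays at the limit.

The step from compound 1 to compound 3 is expected to be an at least 2.5-fold lower number from compound 1 to compound 3 (0.39 log units; beyond the scatter). Compound 3 is therefore estimated at 40000 nM, with a likely range from 5000 nM to 200000 nM.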

Compound 3, half-maximal inhibitory concentration: 25100 nM
Compound 3: middle estimate off by 1.6-fold (0.20 log units), on the high side, within the range that was stated.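

Putting 3-methylphenyl in place of pyridin-3-yl on the oxygen turns a read-out without a number into a measurable one in this assay, with an at least 3.9-fold lower number from compound 1 to compound 3 (0.60 log units; beyond the scatter). That step gives only a minimum size, and the true change may be larger, because compound 1 has a limit of the assay rather than a measured number: the limit of > 100000 nM in this assay, at which 1 of the 3 values shown sits. The result shows that the group on this oxygen can change inhibition on the shared core, as the exchange of a ring with one nitrogen for a carbon-only ring carrying a methyl is enough to bring compound 3 to 25100 nM.

The exchange changes two things at once, removing the ring nitrogen and adding the methyl, so this single step cannot say which of them matters; an unsubstituted phenyl on the oxygen would separate the two. Also open, on these data alone, is how a longer chain, an amine or a carboxylic acid in place of the methyl would read out, and whether any such group could take the shared core further along the scale.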